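Extending the ketone chain on a glutamate receptor modulator

The source may hold more compounds than are shown below. What is called first, only, known or untested is meant among the compounds shown, and "the series" means these compounds.

Measured compounds:
compound 1, `Cc1ccc(C(=O)O)cc1OCCCCOc1ccc(C(=O)CC(C)C)c(O)c1C`, 454 nM;
compound 2, `COc1ccc(C(=O)O)cc1OCCCCOc1ccc(C(C)=O)c(O)c1C`, 1090 nM.

Both compounds were tested in an assay on HEK293 cells for positive allosteric modulation of metabotropic glutamate receptor 2 (Rattus norvegicus), read by thallium flux, with a stated time of 2.5 min; on this read-out lower numbers stand for an effect already at smaller amounts and higher numbers for an effect only at larger amounts of compound. Compound 2 has the higher of the two numbers, and its gap to compound 1 is beyond the usual scatter, so compound 1 acts at smaller amounts. The two compounds differ in more than one place, so no single structural cause can be read from that gap.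

Compound 3, `COc1ccc(C(=O)O)cc1OCCCCOc1ccc(C(=O)CC(C)C)c(O)c1C`, has not yet been measured. It changes compound 2 in one place only: isopropyl in place of hydrogen on a saturated chain carbon bound to a carbonyl carbon. In other words, the acetyl of compound 2 becomes the isobutylcarbonyl found in compound 1, while the methoxy group of compound 2 is kept.

Compound 1 carries this longer ketone chain and shows the lower number, so the step from compound 2 to compound 3 is expected to move toward smaller amounts, with a size estimated as a 2.2-fold lower number from compound 2 to compound 3 (0.34 log units; beyond the scatter). Compound 3 is therefore expected to give about 500 nM, within a range from 200 nM to 1200 nM.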

Compound 3, half-maximal effective concentration: 155 nM
Compound 3: the middle estimate sits 3.2-fold (0.51 log units) above what was measured; the measured number lies below the stated range.
By their numbers in this assay, from the lowest: compound 3; then compound 1; then compound 2.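

In this assay, isopropyl in place of hydrogen on a saturated chain carbon bound to a carbonyl carbon, which turns acetyl into isobutylcarbonyl while the methoxy group stays, gives a 7.0-fold lower number from compound 2 to compound 3 (0.85 log units; beyond the scatter), so this change can now be read on its own and it clearly favours the longer ketone chain. Methoxy in place of methyl on an aromatic carbon, with the isobutylcarbonyl held constant, gives a 2.9-fold lower number from compound 1 to compound 3 (0.47 log units; beyond the scatter), which shows that this second place also matters, and that here the methoxy group goes with the lower number. Nothing measured here explains why either change lowers the number.

The compounds shown leave open whether the ketone chain acts through its length or through its branching, a question that a straight butyl chain or a cyclopentyl group in the same place could help to answer. From the compounds shown here alone, each step has also been read in only one setting, so it remains unknown whether the methoxy step would have the same size alongside the acetyl group, or how an ethoxy group would compare with methoxy.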